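The source may report more compounds than this note shows. Statements on the series, on what has been measured and on what is new or still open speak of the compounds shown alone.

Three compounds have a measured number:
compound 1, `CCOC(=O)C(C)C(O)(c1ccc(OC)c(OC)c1OC)c1cccc2ccccc12`, 4000 nM
compound 2, `COc1cc(COC(c2ccc(OC)c(OC)c2OC)c2cccc3ccccc23)cc(OC)c1`, 17500 nM
compound 3, `C=CCC(O)(c1ccc(OC)c(OC)c1OC)c1cccc2ccccc12`, 10700 nM

In a functional assay on A549 cells (Homo sapiens) for inhibition, read by sulforhodamine B assay, with a stated time of 48 h (on this read-out higher numbers stand for weaker inhibition and lower numbers for stronger inhibition), compound 2 gives 17500 nM, the highest of the three numbers. Its gap to compound 3 lies within the scatter of repeated measurements; its gap to compound 1 lies beyond it, compound 1 giving 4000 nM in this assay.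

The piece turns to compound 4, `C=CCOC(c1ccc(OC)c(OC)c1OC)c1cccc2ccccc12`, which has not been measured. Against compound 2 it shows one change: vinyl in place of 3,5-dimethoxyphenyl on a saturated chain carbon bound to an oxygen on a saturated carbon.

Going by the values given here, only one measured step exists, a 2.7-fold higher number from compound 1 to compound 3 (0.43 log units; beyond the scatter), and it sits on the saturated chain carbon bound to two aromatic carbons, not on the carbon that carries the change here. It shows that swapping a larger group for a small unsaturated one on the shared core moved the number modestly upward. Among the compounds with values here, no step touches the carbon where compound 4 differs from compound 2, so the account expects a step in this assay that stays within the scatter, with a slight lean toward a lower number given that compound 3, with an allyl on the core, gives 10700 nM.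

Compound 4 is therefore estimated at 14000 nM, between 5000 nM and 40000 nM, an expected change of a 1.3-fold lower number from compound 2 to compound 4 (0.10 log units; within the scatter).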

Compound 4, half-maximal inhibitory concentration: 9710 nM
Compound 4: the middle estimate sits 1.4-fold (0.16 log units) above what was measured; measured number inside the range.
By their numbers in this assay, from the lowest: compound 1; then compounds 4, 3 and 2 (each within the scatter of the next).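

Read in this assay, the step of a 1.8-fold lower number from compound 2 to compound 4 (0.26 log units; within the scatter) is the first one on the saturated chain carbon bound to an oxygen on a saturated carbon, since the earlier step sat at a different place on the shared core. It shows that, at this position, 3,5-dimethoxyphenyl with its 10 heavy atoms and one aromatic ring can give way to vinyl with 2 heavy atoms and no ring, while the number stays within the scatter, so this single exchange gives no sign that the assay registers the loss of that ring. Nothing measured alongside these compounds offers an explanation for this result.

The compounds shown leave open whether an amine, a carboxylic acid or a longer saturated chain in place of the vinyl would carry the number beyond the scatter. Going by these compounds alone, they also leave open whether the same exchange of 3,5-dimethoxybenzyl to allyl would read the same way on a core that differs from the one shared by compound 2 and compound 4.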